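Cyclohexylmethyl amide in the benzylidene succinimide series

The source may report more compounds than this note shows. Statements on the series, on what has been measured and on what is new or still open speak of the compounds shown alone.

Compound 1 `CCc1ccc(NC(=O)c2cccc(/C=C3\CC(=O)N(c4ccccc4)C3=O)c2)cc1` and compound 2 `CCc1cccc(NC(=O)c2cccc(/C=C3\CC(=O)N(Cc4ccccc4)C3=O)c2)c1` share the core and differ in the amide substituent and in the group on the imide nitrogen. In an ADME assay on NCM460 cells (Homo sapiens) for cytotoxicity, read by MTT assay, with a stated time of 72 h (on this read-out lower numbers stand for stronger inhibition and higher numbers for weaker inhibition), compound 1 gives only a limit, > 100000 nM. In this assay compound 2 likewise gives only a limit, > 100000 nM. Among the measured compounds shown here, compound 1 therefore stands at the limit of the assay, and both values shown sit there (the limit of > 100000 nM in this assay, at which 2 of the 2 values shown sit), so no step between measured compounds can be sized.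

Compound 3 `O=C(NCC1CCCCC1)c1cccc(/C=C2\CC(=O)N(c3ccccc3)C2=O)c1` differs from compound 1 by cyclohexylmethyl in place of 4-ethylphenyl on an amide-type nitrogen. With both measured values at the limit, the step from compound 1 to compound 3 in this assay is expected to be none beyond the scatter, as a step that the limit leaves unreadable from compound 1 to compound 3. Compound 3 is expected to give 150000 nM in this assay, in the range 60000 nM to 400000 nM, most likely again reported only as a limit.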

Compound 3, half-maximal inhibitory concentration: > 100000 nM
Compound 3: only a limit was reported; the forecaster's own chance of this, stated with the estimate: 80%; the middle value is on the limit's open side.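

In this assay compound 3 gives only a limit, > 100000 nM. Among the compounds shown here, no step from compound 1 to compound 3 can be read: the limit of > 100000 nM in this assay, at which 3 of the 3 values shown sit. The compounds shown leave open whether the amide substituent or the group on the imide nitrogen has any effect on this read-out.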